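Title: Thiazolyl amide in place of fluorodimethylphenyl

The source may report more compounds than this note shows. Statements on the series, on what has been measured and on what is new or still open speak of the compounds shown alone.

Compound 3 `COc1ccc2nc(C)cc(OCC(=O)Nc3cc(C)c(F)c(C)c3)c2c1` gives 5.5 in a physicochemical assay for lipophilicity, read by HPLC, in phosphate buffer, measured as chromatographic lipophilicity, at pH 7.4 (a higher number here means a more lipophilic compound, a lower number a more polar compound), the second highest of the three numbers measured. Compound 1 `CCCc1cc(OCC(=O)Nc2cc(C)cc(C)c2)c2cc(OC)ccc2n1` gives 6.44 in this assay, and compound 2 `COc1ccc2nc(C)cc(OCC(=O)Nc3cc(C)c(OC)c(C)c3)c2c1` gives 4.99. For the measured compounds named here, the one measured single-point step is a number 0.51 log units higher from compound 2 to compound 3 (beyond the scatter). Compound 4 `COc1ccc2nc(C)cc(OCC(=O)Nc3nc(C)c(C)s3)c2c1` has not been measured; it differs from compound 3 in one place: 4,5-dimethyl-1,3-thiazol-2-yl in place of 4-fluoro-3,5-dimethylphenyl on an amide-type nitrogen. Going by the values given here, no measured step exchanges the ring on the amide nitrogen, so the methoxy-to-fluoro step from compound 2 to compound 3 bears on it only as a sign of how far a change at one ring position moves the number. Since 4,5-dimethyl-1,3-thiazol-2-yl enters with fewer heavy atoms and two hydrogen-bond acceptors where 4-fluoro-3,5-dimethylphenyl had none, a step of a number 1.00 log units lower from compound 3 to compound 4 (beyond the scatter) toward the polar end is expected, larger than the step from compound 2 to compound 3. Compound 4 is therefore estimated at 4.5, within 3.8 to 5.2.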

Compound 4, distribution coefficient: 4.24
The estimate for compound 4 lay 0.26 log units above the measured number, within the range that was stated.
By their numbers in this assay, from the lowest: compound 4; then compound 2; then compound 3; then compound 1.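

In this assay, for the compounds shown here, the exchange of the whole ring on the amide-type nitrogen gives a number 1.26 log units lower from compound 3 to compound 4 (beyond the scatter) and so moves the number further than the one earlier step, a number 0.51 log units higher from compound 2 to compound 3 (beyond the scatter) at a single ring position. This shows that the identity of the ring on the amide-type nitrogen can shift this read-out by more than the methoxy-to-fluoro change did, and it places compound 4 lowest of the four compounds, with the same shared core as compound 2 and compound 3. Nothing measured here accounts for the size of the step.

The compounds shown leave open how much of the step belongs to the thiazole ring itself and how much to its two methyl groups. They also leave open where a pyridine ring or a plain phenyl ring on the same nitrogen would fall.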